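Aryl swap on the amide-type nitrogen: compound 3 to compound 4

A few compounds are considered here, and "the series" means these few. Any claim that something is new, unique, unknown or untested is made for them only; others in the source may bear on it.

Three analogues share one core. In a functional assay on HT-29 cells (Homo sapiens) for cytotoxicity, read by MTT assay, with a stated time of 72 h (on this read-out lower numbers stand for stronger inhibition and higher numbers for weaker inhibition), compound 1 `CCN(CC)CCCNc1nc(-c2ccc(NC(=O)Nc3ccccc3F)cc2)nc2ccsc12` gives 550 nM, compound 2 `CCN(CC)CCCNc1nc(-c2ccc(NC(=O)Nc3ccc(Cl)cc3)cc2)nc2ccsc12` gives 58 nM, and compound 3 `CCN(CC)CCCNc1nc(-c2ccc(NC(=O)Nc3ccccc3Cl)cc2)nc2ccsc12` gives 340 nM. Compound 3 thus holds the second highest number of the three: a 1.6-fold lower number from compound 1 to compound 3 (0.21 log units; within the scatter) lies within the scatter, while a 5.9-fold higher number from compound 2 to compound 3 (0.77 log units; beyond the scatter) lies beyond it. Compound 4 `CCN(CC)CCCNc1nc(-c2ccc(NC(=O)Nc3ccc(C)cc3)cc2)nc2ccsc12` carries 4-methylphenyl in place of 2-chlorophenyl on an amide-type nitrogen. Going by the values given here, two measured steps bear on this change, a 5.9-fold higher number from compound 2 to compound 3 (0.77 log units; beyond the scatter) and a 9.5-fold lower number from compound 1 to compound 2 (0.98 log units; beyond the scatter), and both place 4-chlorophenyl at the lower number. Among the compounds with values here, no measured pair shows whether 4-methylphenyl behaves like 4-chlorophenyl. A modest move to a lower number in this assay is therefore expected, a 3.4-fold lower number from compound 3 to compound 4 (0.53 log units; beyond the scatter). Compound 4 is estimated at 100 nM, with a range from 40 nM to 300 nM.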

Compound 4, half-maximal inhibitory concentration: 1620 nM
Estimate against measurement, compound 4: 16-fold (1.21 log units) below; measured number above the stated range.
By their numbers in this assay, from the lowest: compound 2; then compounds 3 and 1 (each within the scatter of the next); then compound 4.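

At this position, the chloro group of 4-chlorophenyl cannot be exchanged for methyl without loss: in this assay, the change gives a 28-fold higher number from compound 2 to compound 4 (1.45 log units; beyond the scatter). The 4-methylphenyl group also gives higher numbers than both 2-substituted aryl groups, with a 4.8-fold higher number from compound 3 to compound 4 (0.68 log units; beyond the scatter) and a 2.9-fold higher number from compound 1 to compound 4 (0.47 log units; beyond the scatter), so the low number of compound 2 does not extend to this other 4-substituted aryl group.

Nothing shown accounts for the gap between chloro and methyl. Going by these compounds, whether a 4-bromophenyl or 4-aminophenyl group would stand nearer compound 2 or compound 4 remains open.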